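From ethoxycarbonyl to methyl on a shared core

The source may report more compounds than this note shows. Statements on the series, on what has been measured and on what is new or still open speak of the compounds shown alone.

Compound 1 `Oc1nnc(-c2nc3ccccc3o2)o1` gives 1200 nM
Compound 2 `Oc1nnc(-c2nc3cc(Cl)ccc3o2)o1` gives 350 nM
Compound 3 `CCOC(=O)c1ccc2oc(-c3nnc(O)o3)nc2c1` gives 1000 nM

In a functional assay (mast cells) with Rattus norvegicus as the target (on this read-out lower numbers stand for stronger inhibition and higher numbers for weaker inhibition), compound 3 gives 1000 nM and sits level with compound 1, as a 1.2-fold lower number from compound 1 to compound 3 (0.08 log units; within the scatter) shows. Compound 2 has the lowest number of the three, and the data show a 2.9-fold higher number from compound 2 to compound 3 (0.46 log units; beyond the scatter) on that side.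

Compound 4 `Cc1ccc2oc(-c3nnc(O)o3)nc2c1` is still unmeasured. It carries methyl in place of ethoxycarbonyl on an aromatic carbon. Among the compounds with values here, no measured compound carries methyl, so the guidance is indirect. Putting ethoxycarbonyl in place of hydrogen changed nothing beyond the scatter, with a 1.2-fold lower number from compound 1 to compound 3 (0.08 log units; within the scatter) as the evidence. Chloro in place of hydrogen gave a modest move, a 3.4-fold lower number from compound 1 to compound 2 (0.54 log units; beyond the scatter), so a small substituent can matter here. Only a small step is therefore expected in this assay, probably none beyond the scatter. The expected change is a 1.1-fold lower number from compound 3 to compound 4 (0.05 log units; within the scatter), a slight one. For compound 4 the estimate is 900 nM, with an expected range from 350 nM to 2000 nM as its limits.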

Compound 4, half-maximal inhibitory concentration: 400 nM
For compound 4 the middle estimate is 2.3-fold (0.35 log units) above the measured one; the range from low to high includes it.
By their numbers in this assay, from the lowest: compounds 2 and 4 (each within the scatter of the next); then compounds 3 and 1 (each within the scatter of the next).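

In this assay, this position on the shared core proves sensitive to the group it carries: methyl in place of ethoxycarbonyl gives a clear shift (a 2.5-fold lower number from compound 3 to compound 4 (0.40 log units; beyond the scatter)). Methyl in place of hydrogen also moves the number beyond the scatter (a 3.0-fold lower number from compound 1 to compound 4 (0.48 log units; beyond the scatter)), so the earlier gain with chloro is no longer a single case, while ethoxycarbonyl goes against this pattern by staying within the scatter of hydrogen. Methyl and chloro cannot be told apart here (a 1.1-fold higher number from compound 2 to compound 4 (0.06 log units; within the scatter)), so two quite different small groups give the same result on this aromatic carbon.

On these data alone, how an amine, a carboxylic acid or a longer chain such as propyl would behave at this position remains open. The data shown offer no measurement that explains why these groups differ.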